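This account rests on a few compounds, and the source may have more. Where it says the series, first, only, none or still open, it means among the compounds named here.

Measured so far in a functional assay for antagonist activity at transient receptor potential cation channel subfamily V member 1 (Homo sapiens), read by FLIPR; a higher number here means a weaker inhibitor, a lower number a stronger inhibitor: compound 1 `CN(C)Cc1cccnc1-c1ccc(C(=O)Nc2ccc(C(C)(C)C)cc2)cc1` gives 746 nM, and compound 2 `CC(C)(C)c1ccc(NC(=O)c2ccc(-c3ncccc3-c3ncc[nH]3)cc2)cc1` gives 3670 nM.

Compound 2 has the higher of the two numbers; the step of a 4.9-fold higher number from compound 1 to compound 2 (0.69 log units; beyond the scatter) lies beyond the scatter. Compound 3 `CC(C)(C)c1ccc(NC(=O)c2ccc(-c3ncccc3-c3nn[nH]n3)cc2)cc1` differs from compound 2 by 2H-tetrazol-5-yl in place of 1H-imidazol-2-yl on an aromatic carbon. Among the compounds with values here, no measured step covers this exchange; the only step known, a 4.9-fold higher number from compound 1 to compound 2 (0.69 log units; beyond the scatter), concerns a different group, so it gives no direction for this one. Compound 3 is therefore expected to stay close to compound 2, with wide uncertainty, as a 1.6-fold higher number from compound 2 to compound 3 (0.21 log units; within the scatter). Compound 3 is estimated at 6000 nM, between 1500 nM and 25000 nM.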

Compound 3, half-maximal inhibitory concentration: > 4000 nM
Compound 3: a limit, no number (the forecaster's own chance of this, stated with the estimate: 15%); the middle value does not contradict the limit.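

In this assay compound 3 gives > 4000 nM, which is a limit of the assay and not a number. At this position, ortho to a large group, 2H-tetrazol-5-yl in place of 1H-imidazol-2-yl gives an at least 1.0-fold higher number from compound 2 to compound 3 (0.03 log units; that floor lies within the scatter), so the two rings cannot be told apart. In place of (dimethylamino)methyl, the same group gives an at least 5.3-fold higher number from compound 1 to compound 3 (0.72 log units; beyond the scatter), so a second five-membered aromatic ring here also falls short of the aminomethyl group. Still open, as far as these compounds go, is how a carboxylic acid or a longer aminoalkyl chain on this aromatic carbon would compare with compound 1.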